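Oxadiazole aryl swap: from methylphenyl to pyridinyl

This account rests on a few compounds, and the source may have more. Where it says the series, first, only, none or still open, it means among the compounds named here.

Measured compounds:
Compound 1, `CS(=O)(=O)c1ccc(-c2cnc3[nH]cc(-c4nnc(-c5ccc(F)cc5)o4)c(=O)c3c2)cc1`, 39.5%
Compound 2, `Cc1ccc(-c2nnc(-c3c[nH]c4ncc(-c5ccc(S(C)(=O)=O)cc5)cc4c3=O)o2)cc1`, 54.8%

Among the compounds with values here, in a functional assay on HCT-116 cells (Homo sapiens) for positive allosteric modulation, read by MTT assay, with stated times of 24 h and 48 h, tested at 2.5 uM (a lower number here means less inhibition of growth, a higher number more inhibition of growth at the concentration tested), compound 2 stands highest of the two numbers known so far; its nearest neighbour is compound 1, which lies lower by the step of a number 15.3 percentage points higher from compound 1 to compound 2 (beyond the scatter), the only measured change, a methyl in place of a fluoro on an aromatic carbon.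

Compound 3, `CS(=O)(=O)c1ccc(-c2cnc3[nH]cc(-c4nnc(-c5cccnc5)o4)c(=O)c3c2)cc1`, has not yet been measured in this assay. It differs from compound 2 by pyridin-3-yl in place of 4-methylphenyl on an aromatic carbon, sitting on an aromatic carbon of the five-membered ring with two nitrogen and one oxygen. Within the data shown here, no measured step exchanges a whole aryl group for a pyridinyl, so the one step in hand bears only loosely on this change; a modest shift in either direction is plausible, and a drop back toward compound 1 is expected. Compound 3 is estimated at 42%, within 25% to 60%, a change of a number 12.8 percentage points lower from compound 2 to compound 3 (beyond the scatter).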

Compound 3, percent growth inhibition at one concentration: 28.6%
Estimate against measurement, compound 3: 13.4 percentage points above; the range from low to high includes it.
By their numbers in this assay, from the lowest: compound 3; then compound 1; then compound 2.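

In this assay, the group on this aromatic carbon of the five-membered ring can move the growth-inhibition number downward as well as upward: pyridin-3-yl in place of 4-methylphenyl gives a number 26.2 percentage points lower from compound 2 to compound 3 (beyond the scatter). The same exchange made against 4-fluorophenyl gives a number 10.9 percentage points lower from compound 1 to compound 3 (beyond the scatter), so the fall appears against both phenyl partners and compound 3 stands lowest of the three. No measurement at hand explains this fall.

The exchange brings a ring nitrogen and removes the methyl or fluoro group together, so these compounds cannot show which of the two changes matters. As far as these compounds go, a plain phenyl group would help separate them, and it remains open how a methyl group or an amine on the pyridine ring would behave.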